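A few compounds are considered here, and "the series" means these few. Any claim that something is new, unique, unknown or untested is made for them only; others in the source may bear on it.

Working notes on the carbamoyl series. Compound 1, `O=C(NCCCCc1ccccc1)n1nnc2ccccc21`, gives 2.1 nM in an assay on HEK293 cells for inhibition of acid ceramidase (Homo sapiens), read by fluorescence, with stated times of 30 min and 1 h; a lower number here means a stronger inhibitor, a higher number a weaker inhibitor. Compound 2, `COc1nc2ccccc2n1C(=O)NCCCCc1ccccc1`, gives 13.9 nM in this assay, the highest of the two numbers; its nearest neighbour is compound 1, which sits clearly below it, beyond the scatter. Compound 3, `O=C(NCCCCc1ccccc1)Nc1nc2ccccc2[nH]1`, reaches only > 10000 nM in this assay, a limit of the assay rather than a number. That result is the limit of > 10000 nM in this assay, at which 1 of the 3 values shown sits.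

Compound 4, `O=C(NCCCCc1ccccc1)n1cnc2ccccc21`, is not yet measured. Against compound 2 it carries hydrogen in place of methoxy on an aromatic carbon, hydrogen in place of methoxy on an aromatic carbon. Within the data shown here, no measured pair covers this change, so the expected size rests on compound 1 at 2.1 nM and compound 2 at 13.9 nM; a moderate step toward a lower number is expected. Compound 4 is expected at 6 nM, within 1.5 nM to 25 nM, which would be a step of a 2.3-fold lower number from compound 2 to compound 4 (0.36 log units; beyond the scatter).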

Compound 4, half-maximal inhibitory concentration: 2.5 nM
For compound 4 the middle estimate is 2.4-fold (0.38 log units) above the measured one; low and high end bracket the measured number.
By their numbers in this assay, from the lowest: compounds 1 and 4 (each within the scatter of the next); then compound 2. At a limit, above all of these: compound 3.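

Hydrogen in place of methoxy on the aromatic carbon between two ring nitrogen atoms gives a 5.6-fold lower number from compound 2 to compound 4 (0.75 log units; beyond the scatter) in this assay, so the methoxy is not required for a low number on this core. Compound 4 and compound 1 lie within the scatter of each other, so this carbon and the ring nitrogen at the same place in compound 1 cannot be told apart here. Nothing measured here bears on the cause of this step. Open, on these data alone, is whether an amine or a methyl at this carbon keeps the number as low as hydrogen does.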